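Trading 2-chlorobenzyl for 4-methylbenzyl on the shared core

The source may report more compounds than this note shows. Statements on the series, on what has been measured and on what is new or still open speak of the compounds shown alone.

In a functional assay on a cell-free system (plasma, Oryctolagus cuniculus) for inhibition, with stated times of 5 min, 1 min and 6 min (a higher number here means a weaker inhibitor, a lower number a stronger inhibitor), compound 1 `CCOC(=O)c1c(C)nc(-c2cccc(C#N)c2)n1C` gives 22100 nM. Compound 2 `CCOC(=O)c1c(C)nc(-c2cccc(C#N)c2)n1OCC(N)=O` reads > 30000 nM, which is a limit of the assay and not a number. Compound 3 `CCOC(=O)c1c(C)nc(-c2cccc(C#N)c2)n1OCc1ccccc1Cl` gives 8710 nM, the lowest number of the three and the strongest inhibitor shown, though still a weak one in absolute terms. Its lead is measured by a 2.5-fold lower number from compound 1 to compound 3 (0.40 log units; beyond the scatter) and by an at least 3.4-fold lower number from compound 2 to compound 3 (0.53 log units; beyond the scatter), while the remaining step, an at least 1.3-fold higher number from compound 1 to compound 2 (0.13 log units; that floor lies within the scatter), has a floor within the scatter.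

Compound 4 `CCOC(=O)c1c(C)nc(-c2cccc(C#N)c2)n1OCc1ccc(C)cc1` keeps everything but the aryl group, with 4-methylphenyl in place of 2-chlorophenyl on a saturated chain carbon bound to an oxygen on an aromatic ring. For the measured compounds named here, no measured step makes a change of this kind. The closest guides are a 2.5-fold lower number from compound 1 to compound 3 (0.40 log units; beyond the scatter) and an at least 3.4-fold lower number from compound 2 to compound 3 (0.53 log units; beyond the scatter), and both bring in the 2-chlorophenyl group rather than exchange it for another aryl group. Since these steps are modest and the new group is of the same size, no large shift is expected. The estimated change, a 1.1-fold higher number from compound 3 to compound 4 (0.06 log units; within the scatter), is expected to stay within the scatter. For compound 4 the estimate in this assay is 10000 nM, with an expected range from 4000 nM to 25000 nM.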

Compound 4, half-maximal inhibitory concentration: 6310 nM
Estimate against measurement, compound 4: 1.6-fold (0.20 log units) above; the measured number falls inside the stated range.
By their numbers in this assay, from the lowest: compounds 4 and 3 (each within the scatter of the next); then compound 1. At a limit, above all of these: compound 2.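

In this assay, 4-methylphenyl in place of 2-chlorophenyl on a saturated chain carbon bound to an oxygen on an aromatic ring gives a 1.4-fold lower number from compound 3 to compound 4 (0.14 log units; within the scatter), so in this pair the exchange of one aryl group for the other cannot be told apart from repeat measurement. The advantage over the methyl on the aromatic nitrogen, until now seen with the (2-chlorobenzyl)oxy group alone, also appears with the (4-methylbenzyl)oxy group, as a 3.5-fold lower number from compound 1 to compound 4 (0.54 log units; beyond the scatter) shows, so it does not depend on the 2-chlorophenyl group. The carbamoyl group compares poorly with this second aryl group too, with an at least 4.7-fold lower number from compound 2 to compound 4 (0.67 log units; beyond the scatter), a step that rests on a limit of the assay and not a number: the limit of > 30000 nM in this assay, at which 1 of the 4 values shown sits.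

The two aryl groups differ both in their substituent and in where it sits, so the compounds shown cannot separate the loss of the 2-chloro group from the arrival of the 4-methyl group. From the compounds shown here alone, it also stays open whether an amine or a carboxylic acid on the aryl group, or a longer chain in place of the benzyl group, would move the number beyond the scatter.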